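Amide series: efficacy notes toward compound 4

The source may hold more compounds than are shown below. What is called first, only, known or untested is meant among the compounds shown, and "the series" means these compounds.

compound 1 `Cc1cccc(C(=O)NCN2CCC(c3nccs3)CC2)c1` — 71%
compound 2 `Cc1cccc(NC(=O)CN2CCC(c3ccc(O)cc3)CC2)c1` — 60%
compound 3 `N#Cc1cccc(C(=O)NCN2CCC(c3cccc[n+]3[O-])CC2)c1` — 69%

All three were read in a functional assay on HEK293 cells for agonist activity at D(4) dopamine receptor (Homo sapiens), read by FLIPR; a lower number here means a smaller maximal response, a higher number a larger maximal response. Among these numbers compound 2 stands lowest; compound 3 lies within the usual scatter of compound 2, while compound 1 lies beyond it. Going by the values given here, no pair of the measured compounds differs in only one place, so no single change has yet been followed within this set.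

Compound 4 `Cc1cccc(NC(=O)CN2CCC(c3ccccc3C#N)CC2)c1` differs from compound 2 by 2-cyanophenyl in place of 4-hydroxyphenyl on a saturated ring carbon. Among the compounds with values here, nothing among the measured compounds tells the size of such a change, so the step of a number 5 percentage points higher from compound 2 to compound 4 (within the scatter) is expected to be modest and probably not beyond the scatter, with no settled direction. Compound 4 is expected to give about 65% in this assay, within a range from 50% to 80%.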

Compound 4, largest response reached (reported as efficacy), in percent of the reference or control that the assay uses: 71%
Compound 4: middle estimate off by 6 percentage points, on the low side, and the stated range covers the measured number.
By their numbers in this assay, from the lowest: compounds 2, 3, 1 and 4 (each within the scatter of the next, the first and the last beyond it).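

In this assay, going by these compounds alone, the group on this saturated ring carbon is the first single change that can be followed in the set: 2-cyanophenyl in place of 4-hydroxyphenyl gives a number 11 percentage points higher from compound 2 to compound 4 (beyond the scatter). The entering group has no hydrogen-bond donor, so a donor on this aryl group is not required for a sizeable maximal response. No supporting data bear on the reason for the step.

The swap changes both the substituent and its place on the aryl ring, and these compounds do not separate the two. On these data alone, whether an unsubstituted phenyl or 2-hydroxyphenyl would track compound 2 or compound 4 remains open.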